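The compounds below may be only part of what the source reports. "The series", "measured", "known", "first", "only" and "open" are said of these compounds alone.

Going by the values given here, in an ADME assay on microsomes from liver (Homo sapiens) for metabolic stability, read by LC-MS, with a stated time of 10 min (a higher number here means that more of the compound is left, a lower number that less of the compound is left), compound 2 `CCN1CCN(c2cccc3c2C[C@H](CN(C)[C@H]2CCCc4cccnc42)NC3)CC1` gives 0%, the lower of the two numbers so far, whereas compound 1 `CN(C[C@H]1Cc2c(cccc2N2CCN(C3COC3)CC2)CN1)[C@H]1CCCc2cccnc21` gives 83.1%. The next structure, compound 3 `CN(C[C@H]1Cc2c(cccc2N2CCNCC2)CN1)[C@H]1CCCc2cccnc21`, changes compound 2 at one place: hydrogen in place of ethyl on an amine nitrogen in a ring. In words, this is hydrogen in place of ethyl on an amine nitrogen in a ring. Among the compounds with values here, only one measured step bears on this change. It sits on the same ring nitrogen and swaps ethyl for oxetan-3-yl: a number 83.1 percentage points lower from compound 1 to compound 2 (beyond the scatter). Within the data shown here, that step is large, so the group on this nitrogen can matter greatly, but no measured compound yet carries hydrogen there. Among the measured compounds shown here, since compound 2 has no compound left to lose, only a rise or no change is possible, and a sizeable rise is expected: a number 50 percentage points higher from compound 2 to compound 3 (beyond the scatter). For compound 3 the estimated value is 50%, with an expected range from 15% to 85%.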

Compound 3, percent of the compound remaining: 99.7%
Estimate against measurement, compound 3: 49.7 percentage points below, outside the stated range (above it).
By their numbers in this assay, from the lowest: compound 2; then compound 1; then compound 3.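

In this assay, going from 4-ethylpiperazin-1-yl to piperazin-1-yl gives a number 99.7 percentage points higher from compound 2 to compound 3 (beyond the scatter) and so shows that the shared core can hold up well when this ring nitrogen carries only hydrogen. Among these three compounds, the very low number therefore goes only with ethyl on this nitrogen, not with every group placed there. Hydrogen also compares directly with oxetan-3-yl, in a number 16.6 percentage points higher from compound 1 to compound 3 (beyond the scatter), which puts hydrogen highest of the three, although nothing shown gives a reason for these differences.

Three groups at one position cannot show whether a methyl, an isopropyl or an acetyl on this nitrogen would follow ethyl or stay close to hydrogen. From the compounds shown here alone, it also stays open whether the same order of groups would hold on a different core.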